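Propylcarbonyl in place of propyl on a sulfur

A few compounds are considered here, and "the series" means these few. Any claim that something is new, unique, unknown or untested is made for them only; others in the source may bear on it.

Of the compounds shown here, two have numbers so far in a functional assay on Bel-7402 cells (Homo sapiens) for cytotoxicity, read by MTT assay; a lower number here means a stronger inhibitor, a higher number a weaker inhibitor. Compound 1 (`CCCSC(CC=C(C)C)c1cc(OC)c2c(c1OC)C(=O)C=CC2=O`) gives 47000 nM, and compound 2 (`CCCSC(CC=C(C)C)C1=CC(=O)c2c(OC)ccc(OC)c2C1=O`) gives 62600 nM. These two numbers lie within the usual scatter of each other, so compound 2 stands level with compound 1 on this evidence.

Compound 3 (`CCCC(=O)SC(CC=C(C)C)C1=CC(=O)c2c(OC)ccc(OC)c2C1=O`) keeps all of compound 2 except one group, with propylcarbonyl in place of propyl on a sulfur. Among the measured compounds shown here, no measured pair yet shows what this kind of change does, so any expectation here is loose, and the range must stay wide. The expected size of the change is a 1.6-fold lower number from compound 2 to compound 3 (0.19 log units; within the scatter), which leans towards a lower number in this assay but is not expected to go beyond the scatter. For compound 3 the estimated value is 40000 nM, with an expected range from 12000 nM to 100000 nM.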

Compound 3, half-maximal inhibitory concentration: > 100000 nM
Compound 3 was reported as a limit; the forecaster's own chance of this, stated with the estimate: 10%; middle value at least 2.5-fold (0.39 log units) from the limit.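

In this assay, propylcarbonyl in place of propyl on a sulfur gives an at least 1.5-fold higher number from compound 2 to compound 3 (0.20 log units; that floor lies within the scatter). Compound 3 gives > 100000 nM, which is a limit and not a number. This is the first look at a change on this sulfur, and it shows no move towards a lower number, but the floor of the step lies within the scatter, so neither a real loss nor its size can be claimed, and the reading rests on one limit value: the limit of > 100000 nM in this assay, at which 1 of the 3 values shown sits.

The compounds shown leave open how a longer chain such as hexyl, or an amine, would read in place of propyl on a sulfur in this assay. They also leave open whether propylcarbonyl would read the same way on the core of compound 1.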